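The source may report more compounds than this note shows. Statements on the series, on what has been measured and on what is new or still open speak of the compounds shown alone.

Of the compounds shown here, three sharing one core have been tested in a functional assay on MC-38 cells (Mus musculus) for antiproliferative activity; a higher number here means a weaker inhibitor, a lower number a stronger inhibitor. Compound 1 `COc1ccc(S(=O)(=O)Nc2cccc3cc[nH]c23)cc1` gives 1.5 ug/mL, the lowest of the three numbers. Compound 2 `Cc1ccc(S(=O)(=O)Nc2cccc3cc[nH]c23)cc1` gives 2.4 ug/mL and compound 3 `Nc1ccc(S(=O)(=O)Nc2cccc3cc[nH]c23)cc1` gives 6.1 ug/mL. The step of a 1.6-fold higher number from compound 1 to compound 2 (0.20 log units; within the scatter) lies within the scatter, whereas a 4.1-fold higher number from compound 1 to compound 3 (0.61 log units; beyond the scatter) and a 2.5-fold higher number from compound 2 to compound 3 (0.41 log units; beyond the scatter) are modest. Compound 4 `COc1ccc(S(=O)(=O)Nc2cccc3c(Cl)c[nH]c23)cc1` differs from compound 1 by chloro in place of hydrogen on an aromatic carbon, sitting on an aromatic carbon of the five-membered aromatic ring with 1 nitrogen. All three measured steps swap groups at a different place on the core, so none of them bears on this change, and the data give no ground to expect a step beyond the scatter. Compound 4 is therefore estimated at 1.5 ug/mL, ranging from 0.5 ug/mL to 4.5 ug/mL, a step of no change at the digits printed from compound 1 to compound 4 (within the scatter).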

Compound 4, half-maximal inhibitory concentration: 0.2 ug/mL
For compound 4 the middle estimate is 7.5-fold (0.88 log units) above the measured one; the measured number lies below the stated range.
By their numbers in this assay, from the lowest: compound 4; then compounds 1 and 2 (each within the scatter of the next); then compound 3.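

In this assay, the carbon on the five-membered aromatic ring, two ring bonds from the ring nitrogen, proves to be a place where a single atom matters: chloro in place of hydrogen gives (a 7.5-fold lower number from compound 1 to compound 4 (0.88 log units; beyond the scatter)). Within the data shown here, the earlier compounds varied only a group elsewhere on the core, so this is the first measured change at this position. Nothing available explains why the number falls.

Going by these compounds, whether bromo or a nitrile at this carbon would do the same remains open. So does whether chloro here would lower the numbers of compound 2 and compound 3 as well.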